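The source may hold more compounds than are shown below. What is called first, only, known or untested is meant among the compounds shown, and "the series" means these compounds.

For the measured compounds named here, compound 1 `Cn1c(N2CCCC2)c(C#N)c2c(N)ncnc21` is one of three compounds measured in an assay on isolated protein for binding affinity to Leucine-rich repeat serine/threonine-protein kinase 2 (Homo sapiens), read by TR-FRET and LanthaScreen, with a stated time of 2 h (a lower number here means a stronger inhibitor, a higher number a weaker inhibitor), where compound 1 gives 41 nM. Compound 2 `C[C@@H]1CCCN1c1c(C#N)c2c(N)nc(Nc3cnn(C)c3)cc2n1C` gives 538 nM in this assay, and compound 3 `C[C@@H]1CCCN1c1c(C#N)c2c(N)nc(Nc3ccn(C)n3)cc2n1C` gives 6 nM. Compound 1 therefore stands second highest of the three numbers: compound 3 sits lower than compound 1 by more than the usual scatter, and compound 2 sits higher, again beyond the scatter. Going by the values given here, the only measured step between close relatives, a 90-fold lower number from compound 2 to compound 3 (1.95 log units; beyond the scatter), changes a group at a part of the molecule that compound 1 does not carry, so it says nothing direct about the change now at hand. That change, (amino in place of pyrrolidin-1-yl on an aromatic carbon), gives compound 4 `Cn1c(N)c(C#N)c2c(N)ncnc21`. Among the compounds with values here, no measured step bears on this swap, so its direction and size are open. Compound 4 is expected to give 150 nM, with a wide range from 30 nM to 800 nM. That estimate means an expected step of a 3.7-fold higher number from compound 1 to compound 4 (0.56 log units; beyond the scatter) in this assay, which would be beyond the scatter only if the number lands toward the edges of that range.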

Compound 4, inhibition constant: 346 nM
Estimate against measurement, compound 4: 2.3-fold (0.36 log units) below; the range from low to high includes it.
By their numbers in this assay, from the lowest: compound 3; then compound 1; then compounds 4 and 2 (each within the scatter of the next).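

In this assay, for the compounds shown here, amino in place of pyrrolidin-1-yl gives an 8.4-fold higher number from compound 1 to compound 4 (0.93 log units; beyond the scatter), the first measured step at this aromatic carbon. The number therefore depends on which group sits here, and among these two groups the pyrrolidin-1-yl ring goes with the lower number, even though amino adds a hydrogen-bond donor that pyrrolidin-1-yl lacks. Nothing available explains why this swap raises the number.

A single step cannot separate the loss of the ring from the loss of its carbons or the arrival of the nitrogen's hydrogens; groups such as dimethylamino, diethylamino or piperidin-1-yl at this carbon would help tell these apart. As far as these compounds go, whether the same swap gives a step of similar size on the core of compound 3 also remains open.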